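Removing a Methyl from the Benzylthio Arm

The source may report more compounds than this note shows. Statements on the series, on what has been measured and on what is new or still open speak of the compounds shown alone.

Two compounds share a core in which a propargylamine sits on a bicyclic scaffold and a benzylthio group hangs from the aromatic ring. Compound 1 is `C#CCNC1CCc2c(SCc3cccc(C)c3)cccc21` and compound 2 is `C#CCNC1CCc2c(SCc3ccc(F)cc3F)cccc21`. Both were tested in an ADME assay on isolated protein for inhibition of Amine oxidase [flavin-containing] B (Homo sapiens); on this read-out higher numbers stand for weaker inhibition and lower numbers for stronger inhibition. For compound 1 the result is only a limit of the assay, > 100000 nM, so its true value is not known beyond that boundary. Compound 2 gives 1480 nM in this assay. Compound 1 stands at the limit of > 100000 nM in this assay, at which 1 of the 2 values shown sits, which means it cannot be ranked against compound 2 by a measured step.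

Compound 3 is `C#CCNC1CCc2c(SCc3ccccc3)cccc21`, not yet measured. It differs from compound 1 by hydrogen in place of methyl on an aromatic carbon. Among the compounds with values here, with only a limit for compound 1, no measured step frames the change, so the expectation rests on the spread between compound 1 and compound 2. A modest gain in inhibition is expected, and the estimated step from compound 1 to compound 3 is an at least 12-fold lower number from compound 1 to compound 3 (1.09 log units; beyond the scatter). Compound 3 is therefore expected to give about 8000 nM in this assay, within a range of 800 nM to 100000 nM.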

Compound 3, half-maximal inhibitory concentration: "not active" (no number reported)
Compound 3: no number reported; the estimate stays without a comparison.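

In this assay, within the data shown here, compound 3 is reported as not active, with no number, so no step from compound 1 to compound 3 can be read. Compound 1 has only a limit of the assay: the limit of > 100000 nM in this assay, at which 1 of the 3 values shown sits. From the compounds shown here alone, whether changing 3-methylphenyl to phenyl alters inhibition at all, and by how much, stays open.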